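Polyol side-chain variants and liver fraction stability

A few compounds are considered here, and "the series" means these few. Any claim that something is new, unique, unknown or untested is made for them only; others in the source may bear on it.

Compound 1 `COc1cc(C2CN(C(=O)c3cc(OC[C@H](O)CO)ccn3)C2)ccc1OCc1ccc(C2CC2)cc1` gives 67% in an ADME assay on S9 fraction from liver (Rattus norvegicus, strain Sprague-Dawley) for metabolic stability, read by LC-MS, using NADPH, with stated times of 5 min and 60 min, tested at 5 uM; on this read-out lower numbers stand for a less stable compound and higher numbers for a more stable compound.
Compound 2 `COc1cc(C2CN(C(=O)c3cc(OC[C@@H](O)CO)ccn3)C2)ccc1OCc1ccc(C2CC2)cc1` gives 61% in this assay.
Compound 3 `COc1cc(C2CN(C(=O)c3cc(COCC(CO)(CO)CO)ccn3)C2)ccc1OCc1ccc(C2CC2)cc1` gives 73% in this assay.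

Compound 1 stands second highest of the three numbers. Its nearest neighbour is compound 2, with a number 6 percentage points lower from compound 1 to compound 2 (within the scatter); this pair is joined by the fact that compounds 1 and 2 differ only in the configuration as drawn, so the two numbers are read as the same. Its furthest neighbour is compound 3, with a number 6 percentage points higher from compound 1 to compound 3 (within the scatter), again within the scatter. Only a number 12 percentage points higher from compound 2 to compound 3 (beyond the scatter) reaches beyond the scatter, and that step is modest.

Compound 4 `COc1cc(C2CN(C(=O)c3cc(COCC(CO)CO)ccn3)C2)ccc1OCc1ccc(C2CC2)cc1` is the next member. Relative to compound 1 the change is (3-hydroxy-2-(hydroxymethyl)propoxy)methyl in place of 2,3-dihydroxypropoxy on an aromatic carbon. The closest measured precedent is the step to compound 3, where the same 2,3-dihydroxypropoxy group left and a larger (3-hydroxy-2,2-bis(hydroxymethyl)propoxy)methyl group entered, moving the number by a number 6 percentage points higher from compound 1 to compound 3 (within the scatter); from compound 2 the same exchange gave a number 12 percentage points higher from compound 2 to compound 3 (beyond the scatter). The entering group in compound 4 carries one hydroxymethyl fewer than that of compound 3, so no step beyond the scatter is expected in this assay, with a slight lean upward.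

Compound 4 is therefore expected to give 70% in this assay, within 58% to 82%, which means an estimated a number 3 percentage points higher from compound 1 to compound 4 (within the scatter).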

Compound 4, percent of the compound remaining: 29%
Beside the measured number, compound 4's estimate is 41 percentage points above it; measured number outside the range, below it.
By their numbers in this assay, from the lowest: compound 4; then compounds 2, 1 and 3 (each within the scatter of the next, the first and the last beyond it).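

In this assay the exchange on the aromatic carbon opposite the ring nitrogen gives a number 38 percentage points lower from compound 1 to compound 4 (beyond the scatter) and a number 32 percentage points lower from compound 2 to compound 4 (beyond the scatter) even though the leaving and entering groups have the same counts of hydrogen-bond donors and acceptors, so this position is more sensitive to the shape of the polyol chain than compounds 1, 2 and 3 alone showed. The sharpest reading is a number 44 percentage points lower from compound 3 to compound 4 (beyond the scatter) with only one hydroxymethyl replaced by hydrogen on the saturated chain carbon, which shows that the methyl-linked ether chain does not by itself set the low number and that, in this pair, the number follows that single hydroxymethyl. No measured property among these compounds accounts for the fall.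

Open, as far as these compounds go, is whether the hydrogen on that chain carbon is what matters, or whether any small group there would hold the number; a methyl or a fluorine on that carbon would separate these readings. Also open, from the compounds shown here alone, is how a carboxylic acid or an amine at the end of the chain would read at this position, and which part of compound 4 is lost in the liver fraction.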